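Extending the ketone chain on a trihydroxy dichloro core

This account rests on a few compounds, and the source may have more. Where it says the series, first, only, none or still open, it means among the compounds named here.

Measured so far:
compound 1, `CCCCCCCC(=O)c1c(OC)c(Cl)c(OC)c(Cl)c1OC`, 15300 nM
compound 2, `CCCC(=O)c1c(O)c(Cl)c(O)c(Cl)c1O`, 21500 nM

Among the measured compounds shown here, compound 2 is one of only two compounds measured in a functional assay on the whole organism (S2 cells, strain S2) for inhibition, with Drosophila as the target, read by a luciferase reporter, with stated times of 1.5 h and 8 h; a higher number here means a weaker inhibitor, a lower number a stronger inhibitor. In this assay compound 2 gives 21500 nM, while compound 1 gives 15300 nM; the two numbers sit within the scatter of each other, so neither compound can be called the stronger or weaker inhibitor, and compound 1 differs from compound 2 at more than one place anyway.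

Compound 3, `CCCCCCCCC(=O)c1c(O)c(Cl)c(O)c(Cl)c1O`, is not yet measured. It differs from compound 2 by pentyl in place of hydrogen on a saturated chain carbon, three bonds along the chain from a carbonyl carbon, that is, the butanoyl chain of compound 2 becomes a nonanoyl chain. For the measured compounds named here, no measured pair shows this change alone, so the expectation rests on little. A modest move toward a lower number is expected, as the step of a 2.2-fold lower number from compound 2 to compound 3 (0.33 log units; beyond the scatter); it may well stay within the scatter. Compound 3 is therefore estimated at 10000 nM, in the range 3000 nM to 40000 nM.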

Compound 3, half-maximal inhibitory concentration: 6500 nM
Compound 3: middle estimate off by 1.5-fold (0.19 log units), on the high side; the measured number falls inside the stated range.
By their numbers in this assay, from the lowest: compound 3; then compounds 1 and 2 (each within the scatter of the next).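

Placing pentyl on a saturated chain carbon, three bonds along the chain from a carbonyl carbon, gives a 3.3-fold lower number from compound 2 to compound 3 (0.52 log units; beyond the scatter) in this assay. This is the first change shown here that moves the number beyond the scatter, so this part of the chain is a place where the assay responds to a structural change, although the step is only modest. Nothing available here accounts for the lower number of the nonanoyl compound.

A single step cannot show whether the number keeps falling as the chain grows, and a dodecanoyl chain would show whether it continues or turns back. It also leaves open whether carbon chain alone matters, which a chain of similar length ending in an amine or a carboxylic acid would test.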